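The source may hold more compounds than are shown below. What is called first, only, known or untested is meant among the compounds shown, and "the series" means these compounds.

Working notes on the series. The shared core carries a triple-bonded arm on the pyrimidinone ring, and only the far end of that arm is varied. Compound 1 `CCCCCC#Cc1cn([C@@H]2O[C@H](CO)[C@@H](O)[C@H](O)[C@H]2O)c(=O)nc1N` ends the arm in pentyl. In a functional assay on L1210 cells (Mus musculus) for cytotoxicity, with a stated time of 48 h (a higher number here means a weaker inhibitor, a lower number a stronger inhibitor), compound 1 reaches only a limit, >= 250000 nM. Compound 2 `Nc1nc(=O)n([C@@H]2O[C@H](CO)[C@@H](O)[C@H](O)[C@H]2O)cc1C#Cc1ccccc1` ends it in phenyl. In this assay compound 2 likewise reports a limit, >= 250000 nM. Within the data shown here, compound 3 `CCCCCc1ccc(C#Cc2cn([C@@H]3O[C@H](CO)[C@@H](O)[C@H](O)[C@H]3O)c(=O)nc2N)cc1` carries pentyl on that phenyl, and in this assay compound 3 gives 132000 nM, the one numeric value so far. Two of the three values shown sit at the same limit, (the limit of >= 250000 nM in this assay, at which 2 of the 3 values shown sit).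

So compound 2 stands at the limit, next to compound 1, and only compound 3 gives a number. The steps measured so far: a step that the two limits leave unreadable from compound 1 to compound 2, and an at least 1.8-fold lower number from compound 2 to compound 3 (0.27 log units; that floor lies within the scatter).

Compound 4 `C#Cc1cn([C@@H]2O[C@H](CO)[C@@H](O)[C@H](O)[C@H]2O)c(=O)nc1N` differs from compound 2 by hydrogen in place of phenyl on a triple-bonded carbon. Both steps bear on it, since both vary the end of the same arm. The first is unreadable, the second at best at the edge of the scatter toward compound 3, and enlarging the end is the only move that produced a number. Cutting the end back to hydrogen is expected to leave compound 4 at the limit, with a number no higher from compound 2 to compound 4 (the limit leaves the size open) expected to show no change beyond the scatter. The estimate for compound 4 is 250000 nM, between 100000 nM and 600000 nM.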

Compound 4, half-maximal inhibitory concentration: >= 250000 nM
Compound 4 was reported as a limit (the forecaster's own chance of this, stated with the estimate: 70%); the middle value lies on the limit itself.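

No step from compound 4 to compound 1 or compound 2 can be read in this assay, since compound 4 also reports only a limit: the limit of >= 250000 nM in this assay, at which 3 of the 4 values shown sit.

The compounds shown leave open how compound 1, compound 2 and compound 4 compare, and whether ending the arm in hydrogen, pentyl or phenyl makes any difference in this assay.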